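The source may hold more compounds than are shown below. What is called first, only, known or untested is meant among the compounds shown, and "the series" means these compounds.

Of the compounds shown here, three sharing one core have been measured in a functional assay on MCF7 cells (Homo sapiens) for inhibition, with a stated time of 96 h; on this read-out higher numbers stand for weaker inhibition and lower numbers for stronger inhibition. Compound 1 `COc1cc(C(=O)c2cn(-c3ccc(C)cc3)cc2-c2nccs2)cc(OC)c1OC` gives 14 nM. Compound 2 `COc1cc(C(=O)c2cn(-c3ccc(F)cc3)cc2-c2nccs2)cc(OC)c1OC` gives 22 nM in this assay, and compound 3 `COc1cc(C(=O)c2cn(-c3ccc(C)cc3)cc2-c2ccccn2)cc(OC)c1OC` gives 36 nM. Compound 2 differs from compound 1 by fluoro in place of methyl on an aromatic carbon, a change that made a 1.6-fold higher number from compound 1 to compound 2 (0.20 log units; within the scatter). Compound 3 differs from compound 1 in the core, by pyridin-2-yl in place of 1,3-thiazol-2-yl on an aromatic carbon, which made a 2.6-fold higher number from compound 1 to compound 3 (0.41 log units; beyond the scatter). Compound 4 `COc1cc(C(=O)c2cn(-c3ccc(F)cc3)cc2-c2ccccn2)cc(OC)c1OC` has not yet been measured in this assay. It differs from compound 3 by fluoro in place of methyl on an aromatic carbon, the same change as that between compound 1 and compound 2, now on the core of compound 3. The step expected in this assay is a 1.6-fold higher number from compound 3 to compound 4 (0.21 log units; within the scatter), resting on the earlier result that the same change gave a 1.6-fold higher number from compound 1 to compound 2 (0.20 log units; within the scatter). Compound 4 is therefore expected to give 58 nM, estimated to lie between 25 nM and 130 nM.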

Compound 4, half-maximal inhibitory concentration: 73 nM
For compound 4 the middle estimate is 1.3-fold (0.10 log units) below the measured one, and the stated range covers the measured number.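

Fluoro in place of methyl on the core of compound 3 made a 2.0-fold higher number from compound 3 to compound 4 (0.31 log units; beyond the scatter), in line with the same change on the core of compound 1: the same change on two cores in this assay, a 1.6-fold higher number (0.20 log units; within the scatter) from compound 1 to compound 2 and a 2.0-fold higher number (0.31 log units; beyond the scatter) from compound 3 to compound 4, 1.3-fold (0.11 log units) apart, within the scatter of two such steps

Pyridin-2-yl in place of 1,3-thiazol-2-yl, carried onto the core of compound 2, made a 3.3-fold higher number from compound 2 to compound 4 (0.52 log units; beyond the scatter), which also matches its earlier step: the same change on two cores in this assay, a 2.6-fold higher number (0.41 log units; beyond the scatter) from compound 1 to compound 3 and a 3.3-fold higher number (0.52 log units; beyond the scatter) from compound 2 to compound 4, 1.3-fold (0.11 log units) apart, within the scatter of two such steps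

Each change therefore carried over between these cores with no difference that can be told from scatter, but this rests on a single pair of cores in this assay and does not show that either step would hold on any other core, nor why it arises.

The compounds shown leave open how a chloro, a methoxy or an amine in place of the methyl would behave on these cores.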